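This account rests on a few compounds, and the source may have more. Where it says the series, first, only, none or still open, it means among the compounds named here.

Compound 1 `COc1cc(NC(=O)/C=C/c2cccc(OCc3ccccc3)c2)cc(OC)c1OC`: 2200 nM
Compound 2 `C=C(Br)C(=O)Nc1cccc(/C=C/C(=O)Nc2ccccc2)c1`: 7300 nM

Both compounds were tested in a functional assay on HeLa cells (Homo sapiens) for inhibition, read by MTT assay, with a stated time of 72 h; a lower number here means a stronger inhibitor, a higher number a weaker inhibitor. Of the two, compound 2 has the higher number, 7300 nM, making it the weaker inhibitor, and its gap to compound 1 lies beyond the scatter. Compound 3 `C=C(Br)C(=O)Nc1cccc(/C=C/C(=O)Nc2ccc(OCC)cc2)c1` has not yet been measured. It is compound 2 with a single change: ethoxy in place of hydrogen on an aromatic carbon. In words, ethoxy takes the place of hydrogen on an aromatic carbon, para to a large group. Among the measured compounds shown here, no two measured compounds differ in only one place, so nothing shows directly what such a change does in this assay. The expectation is therefore a judgement: a modest move towards a lower number, perhaps not beyond the scatter. The expected change is a 2.1-fold lower number from compound 2 to compound 3 (0.32 log units; beyond the scatter). For compound 3 the estimated value is 3500 nM, with an expected range of 900 nM to 12000 nM.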

Compound 3, half-maximal inhibitory concentration: 2000 nM
Estimate against measurement, compound 3: 1.8-fold (0.24 log units) above, within the range that was stated.
By their numbers in this assay, from the lowest: compounds 3 and 1 (each within the scatter of the next); then compound 2.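

In this assay, the position on this ring is not indifferent to what it carries: ethoxy in place of hydrogen on an aromatic carbon, para to a large group, comes with a 3.7-fold lower number from compound 2 to compound 3 (0.56 log units; beyond the scatter) and no other change to the structure. This is the first pair shown that differs in one place, so the effect of a single change can now be read directly, though only for this one group on this one core. Nothing measured here accounts for the step, so its cause remains unknown.

The compounds shown leave open whether the oxygen or the attached carbons matter more, which methoxy or a longer chain such as butoxy could help to separate. On these data alone, how an amine or a carboxylic acid at this place would compare also remains open.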